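A Benzyl Group Enters a Small Bicyclic Core

The source may report more compounds than this note shows. Statements on the series, on what has been measured and on what is new or still open speak of the compounds shown alone.

Compound 1 `COc1ccc(C(=O)Nc2nc(-c3ccc(OC)cc3)nc3cn(-c4ccccc4)nc23)cc1`: 3%
Compound 2 `Nc1nc(-c2ccc(Cl)cc2)nc2cn(-c3ccccc3)nc12`: 13%
Compound 3 `Cc1nc2cn(C)nc2c(=O)[nH]1`: 1%

All three compounds were tested in an assay on CHO cells for displacement of a labelled ligand from adenosine receptor A1 (Homo sapiens), read by scintillation counting, with a stated time of 120 min, tested at 1 uM (on this read-out higher numbers stand for more inhibition at the one concentration tested (going by the name of the read-out) and lower numbers for less inhibition), and each gave only a small number. Compound 3 sits together with compound 1 within the usual scatter of this assay, while compound 2 gives a number that lies beyond the scatter above both of them.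

Compound 4 `Cc1nc2cn(Cc3ccccc3)nc2c(=O)[nH]1` differs from compound 3 in one place: phenyl in place of hydrogen on a saturated chain carbon bound to an aromatic nitrogen. Going by the values given here, no pair of measured compounds separated by a single change is available, so the size of such a step cannot be read from the data. Given that every measured compound stays low in this assay, the change is expected to move the number only within the scatter, if at all. Compound 4 is therefore expected to give 8% in this assay, somewhere between 0% and 25%, an expected step of a number 7 percentage points higher from compound 3 to compound 4 (within the scatter).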

Compound 4, a percentage reported as inhibition, at one concentration (the size of the read-out at that concentration, not a potency): 6%
The estimate for compound 4 lay 2 percentage points above the measured number, and the stated range covers the measured number.
By their numbers in this assay, from the lowest: compounds 3, 1, 4 and 2 (each within the scatter of the next, the first and the last beyond it).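

In this assay the step is a number 5 percentage points higher from compound 3 to compound 4 (within the scatter) when phenyl takes the place of hydrogen on a saturated chain carbon bound to an aromatic nitrogen. Going by these compounds alone, this is the first single change that can be read here, and it shows that this position can carry a phenyl while the number stays small and the change stays within the scatter. No measurement offers an explanation for this result. As far as these compounds go, it remains open whether a longer chain at this place, or an amine or a carboxylic acid on the phenyl, would move the number beyond the scatter.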